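The compounds below may be only part of what the source reports. "The series", "measured", "known", "first", "only" and "open" are said of these compounds alone.

Going by the values given here, compound 1, `CC1=C(C(=O)OC(C(F)(F)F)C(F)(F)F)C(c2ccoc2)NC(=O)N1`, is the only compound with a single number in an assay on HeLa cells for displacement of a labelled ligand from adenosine receptor A3 (Homo sapiens), read by radioligand binding, with a stated time of 180 min, tested at 1 uM (a higher number here means more inhibition at the concentration tested (going by the name of the read-out), a lower number less inhibition), where compound 1 gives 1%; a further entry for compound 1 carries no single number. Compound 2, `CC1=C(C(=O)OC(C)C(F)(F)F)C(c2ccoc2)NC(=O)N1`, gives 12%; 5% (2 entries) in this assay. Compound 3, `CC1=C(C(=O)OC(C(F)(F)F)C(F)(F)F)C(c2cccs2)NC(=O)N1`, has not yet been measured there; its change from compound 1 is thiophen-2-yl in place of furan-3-yl on a saturated ring carbon. Among the compounds with values here, no step between measured compounds is known for this change, so the expected a number 3 percentage points higher from compound 1 to compound 3 (within the scatter) is none beyond the scatter. Compound 3 is therefore estimated at 4%, between 0% and 15%.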

Compound 3, a percentage reported as inhibition, at one concentration (the size of the read-out at that concentration, not a potency): 1%
Compound 3: the middle estimate sits 3 percentage points above what was measured, and the stated range covers the measured number.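

In this assay, the first step read at this position is no change at the digits printed from compound 1 to compound 3 (within the scatter), so thiophen-2-yl and furan-3-yl on this saturated ring carbon cannot be told apart with the core of compound 1. Both readings lie close to the floor of the percentage scale, so this one step cannot show whether the number in this assay stays level with other groups at this position. Repeat readings can spread this far: the several entries of compound 2 in this assay, 12%; 5% (2 entries)

From the compounds shown here alone, whether a ring bearing an amine or a carboxylic acid at this carbon would separate from these two stays open. So does whether thiophen-2-yl matches furan-3-yl with the ester of compound 2.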